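The compounds below may be only part of what the source reports. "The series", "measured", "known", "first", "only" and "open" are said of these compounds alone.

Going by the values given here, compound 1, with the structure `COc1ccc(/C=C2\CCC/C(=C\c3cccc(OC)c3OC)C2=O)cc1`, is the only compound here with an outright number. In a functional assay on SW-620 cells (Homo sapiens) for cytotoxicity, read by MTT assay, with a stated time of 72 h (on this read-out higher numbers stand for weaker inhibition and lower numbers for stronger inhibition), compound 1 gives 13600 nM. Compound 2, with the structure `COc1ccc(/C=C2\CCC/C(=C\c3cccc(OC)c3OC)C2=O)c(OC)c1`, carries a methoxy in place of hydrogen on an aromatic carbon. In this assay compound 2 reaches only a limit of the assay, > 20000 nM, rather than a number. The step of an at least 1.4-fold higher number from compound 1 to compound 2 (0.16 log units; that floor lies within the scatter) therefore rests on (the limit of > 20000 nM in this assay, at which 1 of the 2 values shown sits).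

Compound 3, with the structure `COc1cc(/C=C2\CCC/C(=C\c3cccc(OC)c3OC)C2=O)ccc1O`, is not yet measured. It differs from compound 1 by 4-hydroxy-3-methoxyphenyl in place of 4-methoxyphenyl on a double-bonded chain carbon bound to a double-bonded ring carbon. Among the compounds with values here, the one measured step that touches the same ring, from compound 1 to compound 2, added a methoxy and gave, at the floor, a change no larger than the usual scatter, with the true size unknown. For compound 3 a step of similar kind is expected in this assay: no clear change beyond the scatter, with the unknown size of the step to compound 2 leaving room toward weaker inhibition. Compound 3 is thus estimated at 15000 nM, within a range of 6000 nM to 40000 nM, which means an expected step of a 1.1-fold higher number from compound 1 to compound 3 (0.04 log units; within the scatter).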

Compound 3, half-maximal inhibitory concentration: 8600 nM
Beside the measured number, compound 3's estimate is 1.7-fold (0.24 log units) above it, within the range that was stated.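

Putting 4-hydroxy-3-methoxyphenyl in place of 4-methoxyphenyl on a double-bonded chain carbon bound to a double-bonded ring carbon gives, in this assay, a 1.6-fold lower number from compound 1 to compound 3 (0.20 log units; within the scatter). Unlike the step to compound 2, which ends at a limit of the assay and so offers only a floor, this step has a number at both ends, and it shows that this position can carry a ring with a free hydroxy group without a change that can be told from the scatter. The data shown offer no cause for the size of this step.

Going by these compounds, the new group brings a hydroxy and a second methoxy in a single step, so the share of each stays unknown, and a compound with 4-hydroxyphenyl at this position would help to separate them. Also open, on these data alone, is how a group of another kind on this ring, such as an amine or a carboxylic acid, would read in this assay, and whether any change here can move the number beyond the scatter.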